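Extending the Ether Chain on a Bromine-Free Acetophenone Core

This account rests on a few compounds, and the source may have more. Where it says the series, first, only, none or still open, it means among the compounds named here.

Measured so far:
Compound 1, `CCCCCCOc1cc(OC)c(Br)cc1C(C)=O`: 53100000 nM
Compound 2, `CCCCCCOc1cc(OC)ccc1C(C)=O`: 84400000 nM

In a functional assay, with a stated time of 10 min (on this read-out lower numbers stand for stronger inhibition and higher numbers for weaker inhibition), compound 2 gives the highest of the two numbers, though the step is a 1.6-fold higher number from compound 1 to compound 2 (0.20 log units; within the scatter), which is within the scatter. Compound 3, `CCCCCCCCCCCCOc1cc(OC)ccc1C(C)=O`, differs from compound 2 by hexyl in place of hydrogen on a saturated chain carbon, six bonds along the chain from an oxygen on an aromatic ring. Within the data shown here, the only measured step concerns the bromo group, not the chain, so no measured step bears on this change. With nothing to point either way, compound 3 is estimated near compound 2, the expected step being a 1.2-fold lower number from compound 2 to compound 3 (0.08 log units; within the scatter), with a wide range. The estimate for compound 3 is 70000000 nM, between 15000000 nM and 300000000 nM.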

Compound 3, half-maximal inhibitory concentration: 65600000 nM
For compound 3 the middle estimate is 1.1-fold (0.03 log units) above the measured one; measured number inside the range.
By their numbers in this assay, from the lowest: compounds 1, 3 and 2 (each within the scatter of the next).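

In this assay, hexyl in place of hydrogen on a saturated chain carbon, six bonds along the chain from an oxygen on an aromatic ring, gives a 1.3-fold lower number from compound 2 to compound 3 (0.11 log units; within the scatter). Compound 2 and compound 3 therefore cannot be told apart here, so this added length shows no measurable effect on inhibition. No supporting measurement offers an explanation for this result.

Going by these compounds, whether a still longer chain, or a chain ending in an amine or a carboxylic acid, would give a clearly different number remains open. Also open, on these data alone, is how bromo on the shared core would behave alongside the longer chain of compound 3.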